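The source may report more compounds than this note shows. Statements on the series, on what has been measured and on what is new or still open speak of the compounds shown alone.

Measured compounds and values:

Compound 1, `O=S(=O)(NCCNCc1cccc2ccccc12)c1cc(C(F)(F)F)cc(C(F)(F)F)c1`: 22000 nM
Compound 2, `O=S(=O)(NCCCNCc1ccc(C(F)(F)F)cc1)c1cc(C(F)(F)F)cc(C(F)(F)F)c1`: 3300 nM

In a toxicity assay on MCF-10A cells (Homo sapiens) for inhibition, read by MTT assay, with a stated time of 72 h (on this read-out lower numbers stand for stronger inhibition of growth and higher numbers for weaker inhibition of growth), compound 1 gives 22000 nM. In this assay compound 2 gives 3300 nM, the lower of the two numbers. For the measured compounds named here, no single-point step links these two compounds; their values simply show that compound 2 stands well below compound 1, by a gap beyond the usual scatter.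

Compound 3, `O=S(=O)(NCCCNCc1ccc(Cl)cc1)c1cc(C(F)(F)F)cc(C(F)(F)F)c1`, is not yet measured. It differs from compound 2 in one place: chloro in place of trifluoromethyl on an aromatic carbon. The group that leaves, trifluoromethyl, sits on the six-membered aromatic ring of carbon only, para to a large group; the chloro that enters takes the same position, so the change reads as 4-(trifluoromethyl)benzyl to 4-chlorobenzyl.

Going by the values given here, no measured pair shows what this exchange does here, so the expectation rests on compound 2 alone. The step is expected to be small, within or near the scatter, with at most a slight rise in the number, as a 1.4-fold higher number from compound 2 to compound 3 (0.13 log units; within the scatter). For compound 3 the estimated value in this assay is 4500 nM, expected to fall between 1500 nM and 13000 nM.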

Compound 3, concentration for 50% growth inhibition: 2300 nM
Estimate against measurement, compound 3: 2.0-fold (0.29 log units) above; the measured number falls inside the stated range.
By their numbers in this assay, from the lowest: compounds 3 and 2 (each within the scatter of the next); then compound 1.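

In this assay, for the compounds shown here, the exchange gives a 1.4-fold lower number from compound 2 to compound 3 (0.16 log units; within the scatter) and so provides the first single-place comparison. On this aromatic carbon, para to a large group, the read-out does not distinguish chloro from trifluoromethyl, even though the entering group has 1 heavy atom and the leaving group has 4. Thus, for this pair, the 4-(trifluoromethyl)benzyl group can be exchanged for the 4-chlorobenzyl group without a step beyond the scatter, although no measurement available here explains this result.

On these data alone, whether hydrogen, methoxy, nitrile or a carboxylic acid on the same carbon would give a step beyond the scatter remains open, since this one pair says nothing about groups other than chloro and trifluoromethyl. Compound 1 differs from compound 2 in more than one place, so the compounds shown also leave open how the linking chain and the aromatic group on the amine each contribute separately, and whether a longer chain would change the number.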